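Allyl carbamate selenocyanate: expected growth inhibition

The compounds below may be only part of what the source reports. "The series", "measured", "known", "first", "only" and "open" are said of these compounds alone.

Measured compounds:
compound 1, `CCCCOC(=O)Nc1ccc([Se]C#N)cc1`: 20200 nM
compound 2, `Cc1ccc(OC(=O)Nc2ccc([Se][Se]c3ccc(NC(=O)Oc4ccc(C)cc4)cc3)cc2)cc1`: 37700 nM

In a functional assay on MCF7 cells (Homo sapiens) for cytotoxicity, read by MTT assay, with a stated time of 72 h (a higher number here means a weaker inhibitor of growth, a lower number a stronger inhibitor of growth), compound 1 gives 20200 nM. Compound 2 gives 37700 nM in this assay. The gap between these two values is within the scatter, so compound 1 and compound 2 cannot be told apart on the numbers shown; compound 1 stands alongside compound 2 rather than apart from it, and neither is the stronger or weaker inhibitor of growth on this evidence.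

Compound 3, `C=CCOC(=O)Nc1ccc([Se]C#N)cc1`, carries the same core as compound 1 and differs from it only at the carbamate chain: vinyl in place of propyl on a saturated chain carbon bound to an oxygen next to a carbonyl group. Going by the values given here, no measured pair covers this change, so no step size is known for it, and the direction of any effect in this assay is untested. With a shortening of the chain by one carbon and the arrival of a double bond, the step from compound 1 to compound 3 is expected to be small, most likely none beyond the scatter: a 1.0-fold lower number from compound 1 to compound 3 (0.00 log units; within the scatter). For compound 3 the value in this assay is therefore estimated at 20000 nM, within a range of 8000 nM to 50000 nM.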

Compound 3, concentration for total growth inhibition: 43100 nM
Beside the measured number, compound 3's estimate is 2.2-fold (0.33 log units) below it; measured number inside the range.
By their numbers in this assay, from the lowest: compounds 1, 2 and 3 (each within the scatter of the next, the first and the last beyond it).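

In this assay, the carbamate chain proves to be a position that responds to change: on the shared core, butyl to allyl gives a 2.1-fold higher number from compound 1 to compound 3 (0.33 log units; beyond the scatter), a modest step. Read on this one pair, compound 3 is the weaker inhibitor of growth, so the saturated butyl chain of compound 1 cannot be swapped for allyl without a measurable cost in this assay. The swap alters chain length and brings in a double bond in a single move, so this step alone does not assign the shift to either, and nothing on hand accounts for it.

Still open, going by these compounds, is whether chain length or the double bond carries the step, which a saturated propyl chain on the same core would help to separate, while a longer chain such as hexyl would show whether the number keeps moving in the other direction. Also open, on these data alone, is how far this position tolerates other kinds of group, such as a terminal amine or a carboxylic acid, and whether the same chain change reads the same way on a diselenide like compound 2.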